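Swapping a pyridyl for a methylphenyl in a sulfonamide series

A few compounds are considered here, and "the series" means these few. Any claim that something is new, unique, unknown or untested is made for them only; others in the source may bear on it.

Measured compounds:
- Compound 1, `COc1ccc(Cl)cc1S(=O)(=O)Nc1cncc(-c2ccncc2)c1`: 73 nM
- Compound 2, `COc1ccc(C(F)(F)F)cc1S(=O)(=O)Nc1cccnc1`: 183 nM
- Compound 3, `COC(=O)c1ccc(OC)c(S(=O)(=O)Nc2cccnc2)c1`: 1510 nM

In an assay on isolated protein for inhibition of alkaline phosphatase, tissue-nonspecific isozyme (Homo sapiens) (on this read-out lower numbers stand for stronger inhibition and higher numbers for weaker inhibition), compound 1 gives the lowest number of the three, so it is the strongest inhibitor here; compound 2 comes nearest, and compound 3 sits furthest away. Among the compounds with values here, the only single-point comparison available is an 8.3-fold higher number from compound 2 to compound 3 (0.92 log units; beyond the scatter), which concerns a change at a different position of the shared core and therefore says nothing about the ring attached in compound 1.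

Compound 4, `COc1ccc(Cl)cc1S(=O)(=O)Nc1cncc(-c2cccc(C)c2)c1`, differs from compound 1 in one place: 3-methylphenyl in place of pyridin-4-yl on an aromatic carbon. Within the data shown here, no measured pair tests this kind of swap, and compounds 2 and 3 lack any ring at this position, so they offer only indirect context. Among the measured compounds shown here, with no step bearing on it, the expectation is a change of modest size at most, in either direction, and the estimated step of a 1.4-fold higher number from compound 1 to compound 4 (0.14 log units; within the scatter) is centred close to no change. Compound 4 is therefore expected to give about 100 nM, within a range of 30 nM to 350 nM.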

Compound 4, half-maximal inhibitory concentration: 160 nM
Estimate against measurement, compound 4: 1.6-fold (0.20 log units) below, within the range that was stated.
By their numbers in this assay, from the lowest: compound 1; then compounds 4 and 2 (each within the scatter of the next); then compound 3.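

At this position of the shared core, a ring can be exchanged without losing inhibition altogether: in this assay, replacing pyridin-4-yl with 3-methylphenyl weakens inhibition by a modest step that lies beyond the usual scatter (a 2.2-fold higher number from compound 1 to compound 4 (0.34 log units; beyond the scatter)). Within the data shown here, this is the first direct test of the attached ring, as the earlier step concerned a different position on the core. The swap removes the ring nitrogen and adds a methyl in one move, and nothing measured here explains the weaker inhibition.

The compounds shown leave open whether the step follows the lost ring nitrogen, the added methyl or both. A plain phenyl ring would separate those two changes, while pyridin-3-yl would show whether the location of the ring nitrogen matters.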